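The source may report more compounds than this note shows. Statements on the series, on what has been measured and on what is new or still open speak of the compounds shown alone.

Measured so far:
compound 1 `C[C@@H](NC(=O)Nc1ccc(F)cc1)c1ccccc1`: 98%
compound 2 `C[C@H](NC(=O)Nc1ccc(F)cc1)c1ccccc1`: 96%
compound 3 `C[C@H](NC(=O)Nc1ccc(F)cc1F)c1ccccc1`: 101%

All three were tested in an ADME assay on the whole organism with Oryza sativa as the target, tested at 0.1 uM; a higher number here means a weaker effect of the compound at the concentration tested, a lower number a stronger effect. Compound 1 and compound 2 share every atom and bond; their only difference is the two compounds have the same atoms and bonds and differ only in configuration as drawn: 1 of 1 stereo elements differ; a stereocentre at a saturated chain carbon is drawn S in compound 2 and R in compound 1. The result is a number 2 percentage points lower from compound 1 to compound 2 (within the scatter), a small step that goes together with the fact that compounds 1 and 2 differ only in the configuration as drawn. Compound 2 and compound 3 differ by fluoro in place of hydrogen on an aromatic carbon, which gave a number 5 percentage points higher from compound 2 to compound 3 (within the scatter).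

Compound 4 `C[C@@H](NC(=O)Nc1ccc(F)c(F)c1)c1ccccc1` has not yet been measured. It differs from compound 1 by fluoro in place of hydrogen on an aromatic carbon. This is the same kind of change as from compound 2 to compound 3, not the same change: in compound 4 the entering fluoro sits ortho to a fluoro group and meta to a large group, while in compound 3 it sits ortho to a large group and meta to a fluoro group. Beside that earlier step, a step of a number 1 percentage points higher from compound 1 to compound 4 (within the scatter) is expected, resting on a number 5 percentage points higher from compound 2 to compound 3 (within the scatter). Compound 4 is therefore estimated at 99%, most likely between 90% and 105%.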

Compound 4, a percentage reported as activity, at one concentration (the size of the read-out at that concentration, not a potency): 99%
For compound 4 middle estimate and measured number coincide at the digits printed; the measured number falls inside the stated range.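

In this assay, fluoro in place of hydrogen on an aromatic carbon gives a number 1 percentage points higher from compound 1 to compound 4 (within the scatter). Set beside the earlier case, the change looks alike on the two cores as far as these numbers can tell: the same change on two cores in this assay, a number 5 percentage points higher (within the scatter) from compound 2 to compound 3 and a number 1 percentage points higher (within the scatter) from compound 1 to compound 4, 4 percentage points apart, within the scatter of two such steps

For the compounds shown here, this shows only that neither step rises out of the scatter. It does not show that fluoro has no effect at all, or that the same would hold at another place on the ring or on a core with a clearly stronger effect.

The compounds shown leave open whether a different group on this ring, such as chloro, methoxy or a carboxylic acid, would move the number. They also leave open what a longer chain in place of the methyl would do.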